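The compounds below may be only part of what the source reports. "The series", "measured", "known", "first", "only" and "open" are said of these compounds alone.

Measured compounds:
- compound 1 `Cn1c(=O)c(C(=O)Nc2ccc(Oc3ccncc3-c3cccnc3)c(F)c2)nn(-c2ccc(F)c(Cl)c2)c1=O` gives 12500 nM in a functional assay on A549 cells (Homo sapiens) for cytotoxicity, read by MTT assay, with a stated time of 72 h; a higher number here means a weaker inhibitor, a lower number a stronger inhibitor
- compound 2 `O=C(Nc1ccc(Oc2ccncc2-c2cccnc2)c(F)c1)c1nn(-c2ccccc2)c(=O)c2ccccc12` gives 7900 nM in this assay
- compound 3 `Cn1cc(-c2ccccc2)cc(C(=O)Nc2ccc(Oc3ccncc3-c3cccnc3)c(F)c2)c1=O` gives 7600 nM in this assay

All three share the same amine fragment and differ only in the acid half of the amide. Compound 3 sits at the low end of the three numbers, but both compound 2 and compound 1 lie within the scatter of it, so the three acid parts are not separated by this assay.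

Compound 4 `Cn1cc(-c2ccc(F)cc2)cc(C(=O)Nc2ccc(Oc3ccncc3-c3cccnc3)c(F)c2)c1=O` is the next member. Relative to compound 3 the difference is fluoro in place of hydrogen on an aromatic carbon; cut one bond further out it reads phenyl to 4-fluorophenyl. Among the compounds with values here, no measured pair carries this change, so there is no step to lean on. Within the data shown here, the addition is a single fluorine on the outer phenyl, far from the amide, and nothing among the measured compounds suggests it would move the number beyond the scatter. Compound 4 is therefore expected to give 7000 nM, between 3500 nM and 14000 nM, which means an expected step of a 1.1-fold lower number from compound 3 to compound 4 (0.04 log units; within the scatter) of no consequence.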

Compound 4, half-maximal inhibitory concentration: 8300 nM
Compound 4: the middle estimate sits 1.2-fold (0.07 log units) below what was measured; the measured number falls inside the stated range.
By their numbers in this assay, from the lowest: compounds 3, 2, 4 and 1 (each within the scatter of the next).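

In this assay, within the data shown here, the step of a 1.1-fold higher number from compound 3 to compound 4 (0.04 log units; within the scatter) is the first single-change comparison, and it lies within the scatter. Fluoro in place of hydrogen on an aromatic carbon, para to a large group, therefore does not separate compound 4 from compound 3 here, though this one pair is all that speaks for the position. Nothing available gives a reason for this result or a measured property of the fluoro group.

From the compounds shown here alone, whether a methoxy group, an amine or a carboxylic acid at this same place would give a step beyond the scatter remains open. Also open, going by these compounds, is whether fluoro in place of hydrogen would read the same on the phenyl of compound 2, where the acid half of the amide differs.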